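This account rests on a few compounds, and the source may have more. Where it says the series, first, only, none or still open, it means among the compounds named here.

In a functional assay on the whole organism with Rattus norvegicus as the target, with a stated time of 4 h, at a dose of 40 mg/kg by the intraperitoneal route (on this read-out higher numbers stand for more inhibition at the one dose given (going by the name of the read-out) and lower numbers for less inhibition), three compounds have been measured:

Compound 1, `COCc1c(C)nc2c(OCc3ccccc3)cccn12`, gives 99%.
Compound 2, `CCOCc1c(C)nc2c(OCc3ccccc3)cccn12`, gives 84%.
Compound 3, `CSCc1c(C)nc2c(OCc3ccccc3)cccn12`, gives 29%.

Compound 2 differs from compound 1 by one change, (methyl in place of hydrogen on a saturated chain carbon bound to an oxygen on a saturated carbon); this brought a number 15 percentage points lower from compound 1 to compound 2 (beyond the scatter). Compound 3 differs from compound 1 in its core by methylsulfanyl in place of methoxy on a saturated chain carbon bound to an aromatic carbon, and this brought a number 70 percentage points lower from compound 1 to compound 3 (beyond the scatter), while the values of compound 2 and compound 3 show a number 55 percentage points lower from compound 2 to compound 3 (beyond the scatter). Compound 3 stands lowest of the three.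

Compound 4, `CCSCc1c(C)nc2c(OCc3ccccc3)cccn12`, has not yet been measured. It differs from compound 3 by methyl in place of hydrogen on a saturated chain carbon bound to a sulfur. This is the same kind of change as that from compound 1 to compound 2, but the place differs: there the carbon was bound to an oxygen on a saturated carbon, here it is bound to a sulfur. Among the compounds with values here, the one earlier example of this kind of change, compound 1 to compound 2 with a number 15 percentage points lower from compound 1 to compound 2 (beyond the scatter), is the only thing to rest on, so for compound 4 a step of a number 11 percentage points lower from compound 3 to compound 4 (beyond the scatter) is expected. Compound 4 is thus estimated to give about 18%, between 0% and 45%.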

Compound 4, a percentage reported as inhibition, in the whole organism at one dose (the size of the read-out at that dose, not a potency): 36%
The estimate for compound 4 lay 18 percentage points below the measured number, and the stated range covers the measured number.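

In this assay, going from methylsulfanyl to ethylsulfanyl gave a number 7 percentage points higher from compound 3 to compound 4 (within the scatter), whereas setting ethylsulfanyl in place of the oxygen-bearing chains gave a number 48 percentage points lower from compound 2 to compound 4 (beyond the scatter) and a number 63 percentage points lower from compound 1 to compound 4 (beyond the scatter). The added methyl therefore did not behave alike on the oxygen and sulfur chains: the same change on two cores in this assay, a number 15 percentage points lower (beyond the scatter) from compound 1 to compound 2 and a number 7 percentage points higher (within the scatter) from compound 3 to compound 4, 22 percentage points apart, beyond the scatter of two such steps. Within the data shown here, this shows that a step seen with one of these chains cannot simply be carried over to the other, but with only one pair for each chain it does not show that the two would always differ, nor why they differ here.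

The compounds shown leave open what a longer chain, such as propylsulfanyl or propoxy, would do to the inhibition. They also leave open whether an amine in place of the oxygen or sulfur would follow either chain's behaviour.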